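Methoxy to Hydroxy on a Pyrazole-Linked Aryl Series

This account rests on a few compounds, and the source may have more. Where it says the series, first, only, none or still open, it means among the compounds named here.

Measured so far:
- compound 1, `COc1cc(C)cc(-c2c(-c3ccnc(-c4ccc(N(C)C)cc4)c3)cnn2CC#N)c1`: 20%
- compound 2, `COc1cc(C)cc(-c2nn(CC#N)cc2-c2ccnc(-c3ccc(N(C)C)cc3)c2)c1`: 49%
- compound 3, `COc1cc(C)cc(-c2nn(CC#N)cc2-c2ccc(-c3cccc(C(C)=O)c3)nc2)c1`: 95%

Of the compounds shown here, three have been tested in a functional assay on NCI-H322M cells (Homo sapiens) for cytotoxicity, read by sulforhodamine B assay, with a stated time of 48 h, tested at 100 nM; a higher number here means a weaker effect of the compound at the concentration tested, a lower number a stronger effect. Compound 2 stands second highest of the three numbers. Its nearest neighbour is compound 1, which gives 20% in this assay, a number lower than that of compound 2 and beyond the scatter. Compound 3, which gives 95%, lies furthest from compound 2, higher by a margin that is also beyond the scatter.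

The unmeasured compound 4, `Cc1cc(O)cc(-c2nn(CC#N)cc2-c2ccnc(-c3ccc(N(C)C)cc3)c2)c1`, differs from compound 2 in one place: hydrogen in place of methyl on an oxygen on an aromatic ring. Cut one bond further out, this reads methoxy to hydroxy, so 3-methoxy-5-methylphenyl becomes 3-hydroxy-5-methylphenyl.

Among the measured compounds shown here, no pair of measured compounds shows this change, so there is no measured step to lean on. The step from compound 2 to compound 4 in this assay is expected to be small, likely within the scatter or at most a modest rise, as a number 6 percentage points higher from compound 2 to compound 4 (within the scatter). Compound 4 is therefore estimated to give 55% in this assay, expected to fall between 30% and 85%.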

Compound 4, a percentage reported as activity, at one concentration (the size of the read-out at that concentration, not a potency): 93%
Compound 4: middle estimate off by 38 percentage points, on the low side; measured number outside the range, above it.
By their numbers in this assay, from the lowest: compound 1; then compound 2; then compounds 4 and 3 (each within the scatter of the next).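

In this assay, replacing methoxy with hydroxy, which turns 3-methoxy-5-methylphenyl into 3-hydroxy-5-methylphenyl, gives a number 44 percentage points higher from compound 2 to compound 4 (beyond the scatter). The earlier compounds shown here offered no step at this place, and this one shows that the methyl on the oxygen is not a silent detail: swapping that single carbon for hydrogen leaves compound 4 at 93%, a much weaker effect at the concentration tested. Nothing available here accounts for this weakening.

From the compounds shown here alone, whether the same change would weaken the effect on the core of compound 1 or of compound 3 remains open. So does what an ethoxy group, an amine or a fluorine would do in place of the methoxy on the core of compound 2, which would show whether the step is specific to hydroxy.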